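The source may hold more compounds than are shown below. What is called first, only, known or untested is meant among the compounds shown, and "the series" means these compounds.

Compound 1 `CC[C@H]1OC(=O)[C@H](C)[C@@H](O[C@H]2C[C@@](C)(OC)[C@@H](OC(=O)CN(CC)CC)[C@H](C)O2)[C@H](C)[C@@H](O[C@@H]2O[C@H](C)C[C@H](N(C)C)[C@H]2O)[C@](C)(OC)C[C@@H](C)C(=O)N[C@H](C)[C@@H](O)[C@]1(C)O` gives 3.86 in a physicochemical assay for lipophilicity, read by HPLC, measured as chromatographic lipophilicity, at pH 7.4; a lower number here means a more polar compound, a higher number a more lipophilic compound.
Compound 2 `CC[C@H]1OC(=O)[C@H](C)[C@@H](O[C@H]2C[C@@](C)(OC)[C@@H](O)[C@H](C)O2)[C@H](C)[C@@H](O[C@@H]2O[C@H](C)C[C@H](N(C)C)[C@H]2O)[C@](C)(O)C[C@@H](C)CN(C)[C@H](C)[C@@H](OCCCNC(=O)c2c(C)nn(C)c2Cl)[C@]1(C)O` gives 3.01 in this assay.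
Compound 3 `CC[C@H]1OC(=O)[C@H](C)[C@@H](O[C@H]2C[C@@](C)(OC)[C@@H](O)[C@H](C)O2)[C@H](C)[C@@H](O[C@@H]2O[C@H](C)C[C@H](N(C)C)[C@H]2O)[C@](C)(OC)C[C@@H](C)/C(=N\O)[C@H](C)[C@@H](O)[C@]1(C)OCCCNC(C)=O` gives 2.94 in this assay.

Among these three numbers compound 2 holds the second highest place. Compound 1 lies well above it, by a gap that is beyond the usual scatter, while compound 3 lies so close to compound 2 that the two cannot be told apart in this assay.

Compound 4 `CCC(=O)NCCCO[C@@H]1[C@@H](C)N(C)C[C@H](C)C[C@@](C)(O)[C@H](O[C@@H]2O[C@H](C)C[C@H](N(C)C)[C@H]2O)[C@@H](C)[C@H](O[C@H]2C[C@@](C)(OC)[C@@H](O)[C@H](C)O2)[C@@H](C)C(=O)O[C@H](CC)[C@@]1(C)O` keeps the whole core of compound 2 and changes only the group on the amide carbonyl: ethyl in place of 5-chloro-1,3-dimethyl-1H-pyrazol-4-yl on a carbonyl carbon. Going by the values given here, no measured pair in this set shows exactly that exchange, so the size of the step has to be judged from the groups themselves, as they are counted. A chlorinated, twice methylated five-membered aromatic ring gives way to a two-carbon chain, and the reading in this assay is expected to fall by a modest amount, somewhat beyond the scatter. For compound 4 the expected value in this assay is 2.35, within the range 1.75 to 2.95, which means an expected step of a number 0.66 log units lower from compound 2 to compound 4 (beyond the scatter).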

Compound 4, distribution coefficient: 2.74
Estimate against measurement, compound 4: 0.39 log units below, and the stated range covers the measured number.
By their numbers in this assay, from the lowest: compounds 4, 3 and 2 (each within the scatter of the next); then compound 1.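

In this assay, going by these compounds alone, the exchange of 5-chloro-1,3-dimethyl-1H-pyrazol-4-yl for ethyl on a carbonyl carbon gives a number 0.27 log units lower from compound 2 to compound 4 (within the scatter) and is the first single-place step available in this set. At this position, a group of 8 heavy atoms with one five-membered aromatic ring and 2 hydrogen-bond acceptors can thus give way to one of 2 heavy atoms with no ring, and the two compounds still cannot be told apart in this assay. Nothing at hand explains the size of this step.

As far as these compounds go, it remains open whether a carboxylic acid, an amine or a longer chain on the same carbonyl carbon would move the reading beyond the scatter. This single pair also cannot tell whether the same exchange would behave alike on another core.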